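The source may report more compounds than this note shows. Statements on the series, on what has been measured and on what is new or still open speak of the compounds shown alone.

In an ADME assay on NCM460 cells (Homo sapiens) for cytotoxicity, read by MTT assay, with a stated time of 72 h (a higher number here means a weaker inhibitor, a lower number a stronger inhibitor), compound 1 `Cc1ccc(NC(=O)c2cccc(/C=C3\CC(=O)N(c4ccccc4)C3=O)c2)cc1` gives > 100000 nM, which is a limit of the assay rather than a number. Compound 2 `Cc1ccc(NC(=O)c2cccc(/C=C3\CC(=O)N(c4ccccc4)C3=O)c2)cc1C` gives > 100000 nM, also a limit. The step that the two limits leave unreadable from compound 1 to compound 2 therefore has no readable size. Compound 3 `CCOc1ccc(NC(=O)c2cccc(/C=C3\CC(=O)N(Cc4ccccc4)C3=O)c2)cc1` gives > 100000 nM, again a limit and not a measured number. Where compound 3 stands is thus known only as a limit, and the limit of > 100000 nM in this assay, at which 3 of the 3 values shown sit, records that every value in this assay sits at that same point.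

Compound 4 `CCOc1ccc(NC(=O)c2cccc(/C=C3\CC(=O)N(c4ccccc4)C3=O)c2)cc1` differs from compound 3 by phenyl in place of benzyl on an amide-type nitrogen in a ring. Among the compounds with values here, no measured step mirrors this change; the one step recorded, between compound 1 and compound 2, is unreadable because both ends sit at the limit described in the limit of > 100000 nM in this assay, at which 3 of the 3 values shown sit. So the step that the limit leaves unreadable from compound 3 to compound 4 is expected to stay within the scatter of this assay, with no direction to it. Compound 4 is therefore expected to come out near 150000 nM, within 50000 nM to 500000 nM, and most probably to be reported once more only as a limit rather than as a number.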

Compound 4, half-maximal inhibitory concentration: > 100000 nM
Compound 4 ended at the assay's limit (the forecaster's own chance of this, stated with the estimate: 85%); the middle value lies beyond the limit too.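

Within the data shown here, the steps linking compound 4 to compound 1, compound 2 and compound 3 cannot be read, and no new step emerges, because all four compounds sit at one limit rather than at measured numbers: the limit of > 100000 nM in this assay, at which 4 of the 4 values shown sit.

In this assay the compounds shown leave open where any of them lies beyond that limit, and so whether phenyl in place of benzyl, or any other change among them, makes a difference.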